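This account rests on a few compounds, and the source may have more. Where it says the series, first, only, none or still open, it means among the compounds named here.

Measured so far:
compound 1 `Nc1sc(-c2ccc(Cl)cc2)c(-c2ccc(Cl)cc2)c1C(=O)NC1CCC(O)CC1`, 5670 nM
compound 2 `CN1CCN(C(=O)c2c(N)sc(-c3ccc(Cl)cc3)c2-c2ccc(Cl)cc2)CC1`, 13100 nM
compound 3 `COC(=O)c1c(N)sc(-c2ccc(Cl)cc2)c1-c1ccc(Cl)cc1`, 2780 nM

In a functional assay on PC-3 cells (Homo sapiens) for inhibition, read by sulforhodamine B assay, with a stated time of 72 h (on this read-out lower numbers stand for stronger inhibition and higher numbers for weaker inhibition), compound 3 has the lowest number of the three: the steps of a 2.0-fold lower number from compound 1 to compound 3 (0.31 log units; beyond the scatter) and a 4.7-fold lower number from compound 2 to compound 3 (0.67 log units; beyond the scatter) both end at it, and both lie beyond the scatter. Compound 4 `CC(C)CNC(=O)c1c(N)sc(-c2ccc(Cl)cc2)c1-c1ccc(Cl)cc1` is the next compound, not yet measured, and it differs from compound 3 in one place: isobutylamino in place of methoxy on a carbonyl carbon. For the measured compounds named here, the step that bears on this is the one between compound 1 and compound 3, where an amino group on the carbonyl carbon was exchanged for methoxy and gave a 2.0-fold lower number from compound 1 to compound 3 (0.31 log units; beyond the scatter). Compound 4 puts an amino group back on that carbonyl carbon, so a modestly higher number in this assay is expected, roughly the reverse of that step. For compound 4 the estimate is 5000 nM, with a range from 2000 nM to 14000 nM, which means an expected step of a 1.8-fold higher number from compound 3 to compound 4 (0.25 log units; within the scatter).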

Compound 4, half-maximal inhibitory concentration: 13200 nM
Compound 4: the middle estimate sits 2.6-fold (0.42 log units) below what was measured, within the range that was stated.
By their numbers in this assay, from the lowest: compound 3; then compound 1; then compounds 2 and 4 (each within the scatter of the next).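

Methoxy keeps the lowest number against a third group on this carbonyl carbon, with isobutylamino giving a 4.7-fold higher number from compound 3 to compound 4 (0.68 log units; beyond the scatter) in this assay. Isobutylamino and 4-methylpiperazin-1-yl cannot be told apart, with a 1.0-fold higher number from compound 2 to compound 4 (0.00 log units; within the scatter), whereas isobutyl in place of 4-hydroxycyclohexyl on the amide-type nitrogen gives a 2.3-fold higher number from compound 1 to compound 4 (0.37 log units; beyond the scatter), so the group on that nitrogen can still shift the number modestly. Nothing available here explains these steps.

From the compounds shown here alone, it remains open whether ethoxy or a carboxylic acid on this carbonyl carbon would match methoxy, and whether an unsubstituted amino group there would match the larger amides.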